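The compounds below may be only part of what the source reports. "The series", "measured", "known", "first", "only" and "open" are said of these compounds alone.

Compound 1 `CCOC(=O)[C@H](CCC(=O)O)NC(=O)c1ccc(CNc2nc3cc(N)cc(N)c3nc2-c2ccccc2)cc1`: in a functional assay on UO-31 cells (Homo sapiens) for inhibition, read by sulforhodamine B assay, with a stated time of 48 h (a lower number here means a stronger inhibitor of growth, a higher number a weaker inhibitor of growth), compound 1 gives < 100000 nM, which is a limit of the assay rather than a number.
Compound 2 `Nc1cc(N)c2nc(-c3ccccc3)c(NCc3ccc(Cl)c(Cl)c3)nc2c1`: in this assay compound 2 gives < 100000 nM, again a limit and not a number.
Compound 3 `CCOC(=O)[C@H](CCC(=O)O)NC(=O)c1ccc(Oc2nc3cc(N)cc(N)c3nc2-c2ccccc2)cc1`: in this assay compound 3 gives < 50200 nM, also a limit.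

Compound 2 therefore stands nowhere definite on the numbers shown. For the measured compounds named here, all three measured compounds ended at the limit of < 100000 nM in this assay, at which 2 of the 3 values shown sit, or at the limit of < 50200 nM in this assay, at which 1 of the 3 values shown sits, so none of them gives a number to compare with, and no pair of measured compounds differs in only one place. Going by the values given here, there is thus no measured step of any size to lean on.

Compound 4 `Nc1cc(N)c2nc(-c3ccccc3)c(NCc3ccc(F)cc3)nc2c1` is the unmeasured compound. It differs from compound 2 by 4-fluorophenyl in place of 3,4-dichlorophenyl on a saturated chain carbon bound to a nitrogen on an aromatic ring. Without any measured step, the change from compound 2 to compound 4 is expected to stay within the scatter, so the step that the limit leaves unreadable from compound 2 to compound 4 is an estimate of no real movement. Compound 4 is accordingly expected to give about 50000 nM, somewhere between 5000 nM and 100000 nM, and quite possibly only a limit again.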

Compound 4, concentration for total growth inhibition: < 100000 nM
Compound 4 ended at the assay's limit; the forecaster's own chance of this, stated with the estimate: 70%; the middle value lies beyond the limit too.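

Compound 2 and compound 4 both ended at a limit of the assay rather than at a number, so no step can be read between them. Still open is how strongly any compound shown inhibits growth in this assay and whether swapping 3,4-dichlorobenzyl for 4-fluorobenzyl changes that strength at all.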